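The source may report more compounds than this note shows. Statements on the series, on what has been measured and on what is new or still open speak of the compounds shown alone.

Measured so far:
compound 1 `Fc1ccc2nc(-n3ccnn3)n(C3CC3)c2c1` — 1060 nM
compound 2 `CC(C)c1ncncc1-c1nc2cc(F)c(F)cc2n1C1CC1` — 5 nM

In an assay on cells for inhibition of cytochrome P450 11B2, mitochondrial (Homo sapiens), read by HPLC, with a stated time of 90 min (on this read-out higher numbers stand for weaker inhibition and lower numbers for stronger inhibition), compound 2 gives 5 nM, the lowest of the two numbers, while compound 1 gives 1060 nM, a much higher number, a gap well beyond the scatter. Compound 1 and compound 2 differ in more than one place, so their gap cannot be tied to any single change.

Compound 3 `CN(C)c1ncncc1-c1nc2cc(F)c(F)cc2n1C1CC1` differs from compound 2 in one place only: dimethylamino in place of isopropyl on an aromatic carbon. Within the data shown here, no measured pair shows this change by itself, so its effect is not known from these data. The group that leaves and the group that enters are of similar size, so a small step is expected, leaning toward a slightly higher number. The step from compound 2 to compound 3 is expected to be a 2.4-fold higher number from compound 2 to compound 3 (0.38 log units; beyond the scatter), near the edge of the scatter. Compound 3 is therefore expected to give about 12 nM, within a range from 3 nM to 50 nM.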

Compound 3, half-maximal inhibitory concentration: 29 nM
Estimate against measurement, compound 3: 2.4-fold (0.38 log units) below; low and high end bracket the measured number.
By their numbers in this assay, from the lowest: compound 2; then compound 3; then compound 1.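

In this assay, among these compounds, the swap of isopropyl for dimethylamino on this aromatic carbon gives a 5.8-fold higher number from compound 2 to compound 3 (0.76 log units; beyond the scatter) and is the first view of this change on its own. Both groups have 3 heavy atoms, so the number at this position can shift beyond the scatter even when the heavy-atom count stays the same; what changes is that a carbon gives way to a nitrogen and a hydrogen-bond acceptor is added. No measurement at hand says why the number rises.

The compounds shown leave open how a methoxy group, a cyclopropyl ring or a morpholine ring would read on this same aromatic carbon. Among the compounds shown here, with only one pair carrying this change, they also leave open whether the step would be of similar size on a different core.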